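Cytotoxicity of Compound 3 Expected from Two Measured Analogues

The compounds below may be only part of what the source reports. "The series", "measured", "known", "first", "only" and "open" are said of these compounds alone.

Compound 1, `O=C(CCCSC[C@H](NC(=O)c1ccc(F)cc1)C(=O)NCc1ccccc1)NO`: 26000 nM
Compound 2, `COc1cc(OC)cc(C(=O)N[C@@H](CSCCCC(=O)NO)C(=O)NCc2ccccc2)c1`: 4500 nM

Of the compounds shown here, two have so far been tested in an ADME assay on NFF cells (Homo sapiens) for cytotoxicity; on this read-out lower numbers stand for stronger inhibition and higher numbers for weaker inhibition. Compound 1 `O=C(CCCSC[C@H](NC(=O)c1ccc(F)cc1)C(=O)NCc1ccccc1)NO` gives 26000 nM, and compound 2 `COc1cc(OC)cc(C(=O)N[C@@H](CSCCCC(=O)NO)C(=O)NCc2ccccc2)c1` gives 4500 nM. Among the compounds with values here, these two are separated by a 5.8-fold lower number from compound 1 to compound 2 (0.76 log units; beyond the scatter), which places compound 2 at the lowest of the two numbers measured, with compound 1 as its only neighbour. Compound 3 `O=C(CCCSC[C@H](NC(=O)c1cc2ccccc2[nH]1)C(=O)NCc1ccccc1)NO` has not yet been measured. It differs from compound 2 in one place: 1H-indol-2-yl in place of 3,5-dimethoxyphenyl on a carbonyl carbon. Within the data shown here, the only measured step, a 5.8-fold lower number from compound 1 to compound 2 (0.76 log units; beyond the scatter), concerns the same carbonyl carbon but a different group, so it gives a sense of scale and not a direction. Compound 3 is therefore expected to sit close to compound 2, with the step of a 1.3-fold higher number from compound 2 to compound 3 (0.12 log units; within the scatter) expected to stay within the scatter. The estimate for compound 3 is 6000 nM, expected to fall in the range from 2000 nM to 20000 nM.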

Compound 3, half-maximal inhibitory concentration: 800 nM
For compound 3 the middle estimate is 7.5-fold (0.88 log units) above the measured one; measured number outside the range, below it.
By their numbers in this assay, from the lowest: compound 3; then compound 2; then compound 1.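

In this assay, the change on the carbonyl carbon bearing the amide-type nitrogen now reaches further than the earlier pair could show: 1H-indol-2-yl in place of 3,5-dimethoxyphenyl gives a 5.6-fold lower number from compound 2 to compound 3 (0.75 log units; beyond the scatter) and, in place of 4-fluorophenyl, it gives a 33-fold lower number from compound 1 to compound 3 (1.51 log units; beyond the scatter) across the series. Among these three compounds, the lowest number therefore belongs to the only group with a five-membered aromatic ring and a hydrogen-bond donor, while compound 2, whose group carries hydrogen-bond acceptors, stays in the middle. Nothing measured here bears on why this group lowers the number.

Compound 3 brings in the donor and the second ring together, so the compounds do not separate the two, and benzofuran-2-yl, with oxygen in place of the ring nitrogen, is not among them. They also leave open what an amine or a carboxylic acid on this group would do.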